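A few compounds are considered here, and "the series" means these few. Any claim that something is new, unique, unknown or untested is made for them only; others in the source may bear on it.

Working notes on the series. All three compounds share one core and differ only in the group on the six-membered aromatic ring of carbon only. Compound 1 `Fc1ccc(-c2nc3ccccn3c2NC2CCCCC2)cc1` carries fluoro there, compound 2 `Oc1ccc(-c2nc3ccccn3c2NC2CCCCC2)cc1` carries hydroxy, and compound 3 `Cc1ccc(-c2nc3ccccn3c2NC2CCCCC2)cc1`, not yet measured, carries methyl.

In an assay on membranes from brain for displacement of a labelled ligand from adenosine receptor A1 (Rattus norvegicus) (a higher number here means a weaker inhibitor, a lower number a stronger inhibitor), compound 1 gives only a limit, > 100000 nM, no number. In this assay, among the measured compounds shown here, compound 2 gives 5530 nM, the only number among the values shown. For the measured compounds named here, the one measured step, an at least 18-fold lower number from compound 1 to compound 2 (1.25 log units; beyond the scatter), can only be bounded, since it rests on (the limit of > 100000 nM in this assay, at which 1 of the 2 values shown sits).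

The change to compound 3 is methyl in place of hydroxy on an aromatic carbon. Methyl, like fluoro, brings no hydrogen-bond donor and no hydrogen-bond acceptor, so compound 3 is expected to sit nearer compound 1 than compound 2 in this assay. Given an at least 18-fold lower number from compound 1 to compound 2 (1.25 log units; beyond the scatter), a large rise in the number is expected, a 9.0-fold higher number from compound 2 to compound 3 (0.96 log units; beyond the scatter), with a real chance that this assay reports only a limit. Compound 3 is estimated at 50000 nM, in the range 10000 nM to 300000 nM.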

Compound 3, inhibition constant: 2060 nM
For compound 3 the middle estimate is 24-fold (1.39 log units) above the measured one, outside the stated range (below it).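

At this position on the six-membered aromatic ring of carbon only, a hydrogen-bond donor and acceptor are not required for a measurable value in this assay: the change from hydroxy to methyl gives a 2.7-fold lower number from compound 2 to compound 3 (0.43 log units; beyond the scatter), so the group without either feature is the stronger of this pair. The series also separates two groups that the hydrogen-bond counts alone would not have distinguished, since methyl in place of fluoro gives an at least 48-fold lower number from compound 1 to compound 3 (1.68 log units; beyond the scatter), and the lack of a donor and an acceptor therefore does not account for the weak result of compound 1. Compound 1 gives only a limit, so this step has a lower bound and no exact size: the limit of > 100000 nM in this assay, at which 1 of the 3 values shown sits.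

With only fluoro, hydroxy and methyl shown, it remains open whether the trend from hydroxy to methyl extends to a longer chain such as ethyl, or whether a methoxy group, which keeps the oxygen of hydroxy but loses its hydrogen, falls nearer compound 2 or compound 3. Equally open, as far as these compounds go, is how an amine or a carboxylic acid at this position would read in this assay.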